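The compounds below may be only part of what the source reports. "The series", "measured", "known", "first", "only" and "open" are said of these compounds alone.

Compound 1, `Cc1c[se]c(N/N=C/c2ccc(Cl)cc2)n1`: 49400 nM in a functional assay on DU-145 cells (Homo sapiens) for cytotoxicity, read by XTT assay, with a stated time of 72 h; on this read-out higher numbers stand for weaker inhibition and lower numbers for stronger inhibition
Compound 2, `ClCc1c[se]c(N/N=C/c2csc(-c3ccccc3)n2)n1`: 16400 nM
Compound 3, `CC(=O)N(/N=C/c1ccc(Cl)cc1)c1nc(C)c[se]1`: 60600 nM

In this assay compound 2 gives the lowest of the three numbers; how its core differs from the core of compound 1 is not broken down here. Compound 3 arises from compound 1 by acetyl in place of hydrogen on a nitrogen on an aromatic ring, and the step of a 1.2-fold higher number from compound 1 to compound 3 (0.09 log units; within the scatter) lies within the scatter. Compound 4, `CC(=O)N(/N=C/c1csc(-c2ccccc2)n1)c1nc(CCl)c[se]1`, has not yet been measured; it arises from compound 2 by the same change, (acetyl in place of hydrogen on a nitrogen on an aromatic ring), at a place described in the same words. Because the measured step of a 1.2-fold higher number from compound 1 to compound 3 (0.09 log units; within the scatter) stayed within the scatter, the expected step is a 1.2-fold higher number from compound 2 to compound 4 (0.09 log units; within the scatter), essentially no change. Compound 4 is therefore estimated at 20000 nM in this assay, with a likely range from 8000 nM to 50000 nM.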

Compound 4, half-maximal inhibitory concentration: 19600 nM
For compound 4 the middle estimate is 1.0-fold (0.01 log units) above the measured one, and the stated range covers the measured number.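

In this assay the new step, a 1.2-fold higher number from compound 2 to compound 4 (0.08 log units; within the scatter), agrees with the earlier one, and acetyl in place of hydrogen on a nitrogen on an aromatic ring stays within the scatter on both cores: the same change on two cores in this assay, a 1.2-fold higher number (0.09 log units; within the scatter) from compound 1 to compound 3 and a 1.2-fold higher number (0.08 log units; within the scatter) from compound 2 to compound 4, 1.0-fold (0.01 log units) apart, within the scatter of two such steps. This shows that, on these two cores, the change leaves the number essentially where it was. Among these compounds, it rests on only two pairs in one cell line, however, and does not show that the same would hold on any other core.

The compounds shown leave open whether a longer acyl chain or a benzoyl group on that nitrogen would behave as acetyl does. They also leave open whether a free amine elsewhere on the core would alter the outcome.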